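Ethynyl for thiophen-2-yl on two related cores

The source may hold more compounds than are shown below. What is called first, only, known or untested is meant among the compounds shown, and "the series" means these compounds.

Measured so far in a functional assay on CEM-DNR-bulk cells (Homo sapiens), read by MTT assay, with a stated time of 72 h; a higher number here means a weaker inhibitor, a lower number a stronger inhibitor:
compound 1 `Cc1nc(N)c2c(-c3cccs3)cn([C@@H]3O[C@H](CO)[C@@H](O)[C@H]3O)c2n1` gives > 20000 nM, a limit of the assay.
compound 2 `COc1nc(N)nc2c1c(-c1cccs1)cn2[C@@H]1O[C@H](CO)[C@@H](O)[C@H]1O` gives > 20000 nM, a limit of the assay.
compound 3 `C#Cc1cn([C@@H]2O[C@H](CO)[C@@H](O)[C@H]2O)c2nc(C)nc(N)c12` gives 12600 nM.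

Compound 1 and compound 3 share one core and differ in a single place: ethynyl in place of thiophen-2-yl on an aromatic carbon. That step is an at least 1.5-fold lower number from compound 1 to compound 3 (0.20 log units; that floor lies within the scatter), and its floor rests on (the limit of > 20000 nM in this assay, at which 2 of the 3 values shown sit). Compound 2 carries a second core; how it differs from compound 1 is not broken down here. Compound 4 `C#Cc1cn([C@@H]2O[C@H](CO)[C@@H](O)[C@H]2O)c2nc(N)nc(OC)c12` is not yet measured. It stands to compound 2 as compound 3 stands to compound 1, the same change at the same place: ethynyl in place of thiophen-2-yl on an aromatic carbon. Since compound 2 is known only as a limit, the step to compound 4 can likewise be read only from a floor. The step from compound 2 to compound 4 is expected to be an at least 1.5-fold lower number from compound 2 to compound 4 (0.18 log units; that floor lies within the scatter), set beside the measured step from compound 1 to compound 3 because compound 2 also sits at the limit of > 20000 nM in this assay, at which 2 of the 3 values shown sit. Compound 4 is therefore expected to give about 13000 nM in this assay, with a range from 5000 nM to 30000 nM and a fair chance that only a limit is returned.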

Compound 4, half-maximal inhibitory concentration: > 20000 nM
Compound 4 ended at the assay's limit; the forecaster's own chance of this, stated with the estimate: 40%; middle value at least 1.5-fold (0.18 log units) from the limit.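

No step from compound 2 to compound 4 can be read in this assay, because both compounds stand at a limit and not at a number: the limit of > 20000 nM in this assay, at which 3 of the 4 values shown sit.

The compounds shown leave open whether ethynyl in place of thiophen-2-yl on an aromatic carbon changes the number at all on the core of compound 2, as it may on the core of compound 1.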